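Isoxazolone to oxadiazolone in an interleukin-2 inhibitor series

The source may hold more compounds than are shown below. What is called first, only, known or untested is meant among the compounds shown, and "the series" means these compounds.

Compound 1 `Cc1ccc(C2=NOC(C)(C)C2=O)cc1-c1cnc(C(=O)Nc2c(F)cccc2F)cn1` — 150 nM
Compound 2 `Cc1ccc(C2=NOC(C)(C)C2=O)cc1-c1ccc(NC(=O)c2c(F)cccc2F)cc1` — 69 nM

In an assay on Jurkat T cells for inhibition of interleukin-2 (Homo sapiens), read by ELISA, with stated times of 10 min and 24 h (on this read-out higher numbers stand for weaker inhibition and lower numbers for stronger inhibition), compound 2 gives 69 nM and stands lowest of the two numbers recorded, with compound 1 at 150 nM, a gap beyond the usual scatter. Compound 3 `Cc1ccc(-c2nn(C)c(=O)o2)cc1-c1ccc(NC(=O)c2c(F)cccc2F)cc1` has not yet been measured. It differs from compound 2 by a group of 7 heavy atoms (3 carbon, 2 nitrogen, 2 oxygen; one five-membered aromatic ring with 3 hetero atoms) in place of a group of 8 heavy atoms (5 carbon, 1 nitrogen, 2 oxygen; one five-membered non-aromatic ring with 2 hetero atoms), on an aromatic carbon, on the aromatic carbon named in that description. Among the measured compounds shown here, no step between two measured compounds mirrors this change, so the direction is open; a modest shift is expected, most likely a slight weakening, a 1.7-fold higher number from compound 2 to compound 3 (0.24 log units; within the scatter). Compound 3 is therefore estimated at 120 nM, within 40 nM to 400 nM.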

Compound 3, half-maximal inhibitory concentration: 34 nM
Compound 3: middle estimate off by 3.5-fold (0.55 log units), on the high side, outside the stated range (below it).
By their numbers in this assay, from the lowest: compound 3; then compound 2; then compound 1.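

In this assay, putting the five-membered aromatic ring with 3 hetero atoms in place of the five-membered non-aromatic ring with 2 hetero atoms gives a 2.0-fold lower number from compound 2 to compound 3 (0.31 log units; beyond the scatter), a modest gain in inhibition. This shows that the group on the aromatic carbon para to a methyl group can be exchanged without loss, which compound 1 and compound 2, sharing that group, could not show. Nothing available explains the gain.

The compounds shown leave open whether the same exchange holds on the core of compound 1. They also leave open how an amine or a carboxylic acid at this place would read.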